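A Methyl on the Ring Nitrogen: Expecting Compound 4

A few compounds are considered here, and "the series" means these few. Any claim that something is new, unique, unknown or untested is made for them only; others in the source may bear on it.

Of the compounds shown here, three have been tested in a functional assay on the whole organism for antagonist activity, with Rattus norvegicus as the target; a lower number here means that less compound is needed, a higher number that more compound is needed for the effect. Compound 1 `CCN(C)c1ncnc2c1ncn2CC1CC1` gives 12.5 mg/kg in this assay, and compound 2 `CCNc1ncnc2c1ncn2CC1CC1` gives 22 mg/kg. Compound 3 `c1nc(NC2CC2)c2ncn(C3CC3)c2n1` gives 4.5 mg/kg; its number is the lowest of the three, and its distance from each of the other two lies beyond the usual scatter.

Compound 1 and compound 2 differ in one place: methyl in place of hydrogen on a nitrogen on an aromatic ring. That change gave a 1.8-fold lower number from compound 2 to compound 1 (0.25 log units; within the scatter), a step that stays within the scatter, so the two numbers cannot be ordered with confidence.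

Compound 4 `CN(c1ncnc2c1ncn2C1CC1)C1CC1` has not yet been measured. It differs from compound 3 in one place: methyl in place of hydrogen on a nitrogen on an aromatic ring. The cores of compound 3 and compound 2 differ in more than one way, and the difference between them is not broken down here. The change from compound 3 to compound 4 is the same kind of change as that from compound 2 to compound 1, but not the same: in compound 1 the other neighbours of the nitrogen are an aromatic carbon and a saturated chain carbon, while in compound 4 they are an aromatic carbon and a saturated ring carbon.

The expectation for compound 4 rests on a single earlier example. Because the step of a 1.8-fold lower number from compound 2 to compound 1 (0.25 log units; within the scatter) was small and within the scatter, the step from compound 3 to compound 4 is expected to be a 1.5-fold lower number from compound 3 to compound 4 (0.18 log units; within the scatter), small as well. Compound 4 is therefore estimated at 3 mg/kg in this assay, with a likely range from 1.2 mg/kg to 8 mg/kg.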

Compound 4, dose for half-maximal effect: 4.5 mg/kg
Compound 4: the middle estimate sits 1.5-fold (0.18 log units) below what was measured, within the range that was stated.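

In this assay, putting methyl in place of hydrogen on the nitrogen of the cyclopropylamino group gave no change at the digits printed from compound 3 to compound 4 (within the scatter). Set beside the earlier example on the other core, the new step cannot be told apart from it, so on these two cores the change behaves alike, with a small step each time: the same change on two cores in this assay, a 1.8-fold lower number (0.25 log units; within the scatter) from compound 2 to compound 1 and no change at the digits printed (within the scatter) from compound 3 to compound 4, 1.8-fold (0.25 log units) apart, within the scatter of two such steps This shows that, for this pair of cores, the earlier step gave a fair guide to the later one, but it does not show that methyl on this nitrogen truly lowers the number or truly leaves it unchanged, since neither step rises above the scatter, and two examples cannot establish a rule for the whole series.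

The compounds shown leave open what happens when the methyl on this nitrogen gives way to a propyl chain, or to a chain ending in a carboxylic acid, where a step might stand clear of the scatter. They also leave open whether the same small step would appear on a third core, or whether the agreement seen here is limited to the two cores compared so far.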